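The source may report more compounds than this note shows. Statements on the series, on what has been measured and on what is new or still open speak of the compounds shown alone.

Compound 1 `CCSC(=O)C1=C(C)NC(=O)NC1c1ccoc1` gives 1% in an assay on membranes from HeLa cells for displacement of a labelled ligand from adenosine receptor A3 (Homo sapiens), read by scintillation counting, with a stated time of 180 min, tested at 1 uM; a higher number here means more inhibition at the concentration tested (going by the name of the read-out), a lower number less inhibition.
Compound 2 `CCSC(=O)C1=C(C)NC(=O)NC1c1cccs1` gives 1% in this assay.
Compound 3 `CCC(CC)OC(=O)C1=C(C)NC(=O)NC1c1ccoc1` gives 5% in this assay.

All three numbers sit close to the floor of this assay, and none of the steps among them moves out of the usual scatter. Compound 1 and compound 2 differ in one place, (thiophen-2-yl in place of furan-3-yl on a saturated ring carbon), and that change gives no change at the digits printed from compound 1 to compound 2 (within the scatter). Compound 3 stands apart from compound 1 by a different exchange, ((pentan-3-yl)oxy in place of ethylsulfanyl on a carbonyl carbon), which gives a number 4 percentage points higher from compound 1 to compound 3 (within the scatter); among the three measured compounds it carries the highest number, but its distance to either of the other two lies within the scatter, so no order among them can be read from these values.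

Compound 4 `CCC(CC)OC(=O)C1=C(C)NC(=O)NC1c1cccs1` has not yet been measured in this assay. It arises from compound 3 by thiophen-2-yl in place of furan-3-yl on a saturated ring carbon. This is the same kind of change that leads from compound 1 to compound 2, not the same change, since the surroundings differ: in the first pair the saturated ring carbon is next to the ring atom that bears a (ethylsulfanyl)carbonyl group (5 heavy atoms), whereas in the second pair it is next to the ring atom that bears a group of 8 heavy atoms. The change occurs twice in all among these compounds.

The step from compound 3 to compound 4 in this assay is expected to be small, a number 1 percentage points lower from compound 3 to compound 4 (within the scatter), because the same kind of change gave no change at the digits printed from compound 1 to compound 2 (within the scatter) and because compound 3 itself sits at 5%, leaving little room for a fall. For compound 4 the estimated inhibition is 4%, with a range from 0% to 12%.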

Compound 4, a percentage reported as inhibition, at one concentration (the size of the read-out at that concentration, not a potency): 1%
For compound 4 the middle estimate is 3 percentage points above the measured one; the measured number falls inside the stated range.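

Thiophen-2-yl in place of furan-3-yl on the saturated ring carbon gives a number 4 percentage points lower from compound 3 to compound 4 (within the scatter), and set beside the same change on the core of compound 1, it shows no difference that stands out from the scatter: the same change on two cores in this assay, no change at the digits printed (within the scatter) from compound 1 to compound 2 and a number 4 percentage points lower (within the scatter) from compound 3 to compound 4, 4 percentage points apart, within the scatter of two such steps

(Pentan-3-yl)oxy in place of ethylsulfanyl on the carbonyl carbon gives no change at the digits printed from compound 2 to compound 4 (within the scatter), and the comparison with the earlier step reads the same way: the same change on two cores in this assay, a number 4 percentage points higher (within the scatter) from compound 1 to compound 3 and no change at the digits printed (within the scatter) from compound 2 to compound 4, 4 percentage points apart, within the scatter of two such steps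

Within this assay, this shows that neither change moved the number beyond the scatter on either core, and that the two changes behaved alike on the two cores as far as these numbers can tell; it does not show that the size of either step carries from one core to another, since all four compounds sit close to the floor of the read-out, where a real difference between cores could stay hidden.

The compounds shown leave open whether a phenyl group in place of thiophen-2-yl, or an amine or a longer chain in place of (pentan-3-yl)oxy, would lift the number clear of the scatter in this assay. Only from such a compound, away from the floor, could a test of carrying either change between cores begin.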